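Removing one methoxy group from the aryl ring of compound 1

This account rests on a few compounds, and the source may have more. Where it says the series, first, only, none or still open, it means among the compounds named here.

Going by the values given here, compound 1 `COc1ccc(-c2nnc(SCC(=O)c3ccccc3)n2-c2ccccc2)cc1OC` is one of three compounds measured so far in a functional assay on the whole organism (strain albino) for inhibition, with Rattus norvegicus as the target, read by paw edema, with a stated time of 5 h, at a dose of 0.28 mmol/kg by the oral route (on this read-out higher numbers stand for more inhibition at the one dose given (going by the name of the read-out) and lower numbers for less inhibition), where compound 1 gives 59%. Compound 2 `C=CCn1c(SCC(=O)c2ccccc2)nnc1-c1ccc(OC)c(OC)c1` gives 62% and compound 3 `CCn1c(SCC(=O)c2ccccc2)nnc1-c1ccc(OC)c(OC)c1` gives 69%. Compound 1 has the lowest of the three numbers, but the steps of a number 3 percentage points higher from compound 1 to compound 2 (within the scatter) and a number 10 percentage points higher from compound 1 to compound 3 (within the scatter) are both within the scatter, as is a number 7 percentage points higher from compound 2 to compound 3 (within the scatter), so the three values cannot be ordered.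

Compound 4 `COc1ccc(-c2nnc(SCC(=O)c3ccccc3)n2-c2ccccc2)cc1` differs from compound 1 in hydrogen in place of methoxy on an aromatic carbon; cut one bond further out, the change reads 3,4-dimethoxyphenyl to 4-methoxyphenyl. Among the compounds with values here, none of the measured steps touches this part of the structure: all three concern the group on the aromatic nitrogen, and all three lie within the scatter. Nothing measured therefore points to a step beyond the scatter in either direction for this change. The expected step is a number 3 percentage points lower from compound 1 to compound 4 (within the scatter). Compound 4 is estimated to give 56% in this assay, with a range from 40% to 70%.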

Compound 4, a percentage reported as inhibition, in the whole organism at one dose (the size of the read-out at that dose, not a potency): 61%
The estimate for compound 4 lay 5 percentage points below the measured number; the range from low to high includes it.
By their numbers in this assay, from the lowest: compounds 1, 4, 2 and 3 (each within the scatter of the next).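

In this assay, going by these compounds alone, this is the first step on the aryl ring rather than on the group on the aromatic nitrogen: hydrogen in place of methoxy gives a number 2 percentage points higher from compound 1 to compound 4 (within the scatter). With phenyl on the aromatic nitrogen, the methoxy group that stands ortho to a methoxy group and meta to a large group can therefore be lost from the 3,4-dimethoxyphenyl ring, leaving 4-methoxyphenyl, with no step beyond the scatter at this single dose. No evidence is at hand that would explain this result.

Going by these compounds, it remains open whether the same change behaves alike with ethyl or allyl on the aromatic nitrogen, and what loss of the remaining methoxy group would do. Also open, on these data alone, is whether a hydroxy group, an amine or a chlorine atom at this position would move the number beyond the scatter.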